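Removing a Chloro Group from a Pyrazoline Hydrazide

This account rests on a few compounds, and the source may have more. Where it says the series, first, only, none or still open, it means among the compounds named here.

Measured so far:
Compound 1, `O=C(NN1CCCC1)C1=NN(c2ccc(Cl)cc2Cl)C(c2ccc(Cl)cc2)C1`, gives 2.5%.
Compound 2, `O=C(NN1CCOCC1)C1=NN(c2ccc(Cl)cc2)C(c2ccc(Cl)cc2)C1`, gives 8.1%.

Both compounds were tested in a functional assay on the whole organism (strain Zucker) for inhibition, with Rattus norvegicus as the target, with a stated time of 4 h, at a dose of 10 mg/kg by the oral route; on this read-out higher numbers stand for more inhibition at the one dose given (going by the name of the read-out) and lower numbers for less inhibition. Compound 1 and compound 2 share a core and differ in the aryl ring attached to the ring nitrogen and in the cyclic amine on the hydrazide. Compound 2 sits at the larger of the two numbers, but its value and that of compound 1 lie within the usual scatter of each other, so neither compound can be set above the other; both show little inhibition at this dose.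

Compound 3, `O=C(NN1CCOCC1)C1=NN(c2ccccc2)C(c2ccc(Cl)cc2)C1`, has not yet been tested in this assay. It differs from compound 2 in one place: hydrogen in place of chloro on an aromatic carbon. Going by the values given here, no step between two measured compounds isolates this change, so there is no precedent to lean on. Because compound 2 gives 8.1%, a low read-out, the step of a number 3.1 percentage points lower from compound 2 to compound 3 (within the scatter) is expected to stay within the scatter, with no change that could be told apart from noise. Compound 3 is therefore estimated at 5%, between -6% and 18%.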

Compound 3, a percentage reported as inhibition, in the whole organism at one dose (the size of the read-out at that dose, not a potency): 0.5%
Estimate against measurement, compound 3: 4.5 percentage points above, and the stated range covers the measured number.
By their numbers in this assay, from the lowest: compounds 3, 1 and 2 (each within the scatter of the next).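

Going by these compounds alone, compound 2 and compound 3 form the first pair that differs in one place only, so this is the first direct look at what the chloro group contributes at this position. Replacing 4-chlorophenyl with phenyl gives a number 7.6 percentage points lower from compound 2 to compound 3 (within the scatter) in this assay, so removing this chloro group, with hydrogen taking its place, produces no difference that can be told apart from noise, and the pair reads low on both sides. Nothing measured here explains these numbers, and a step this small offers nothing to explain.

Because both compounds show little inhibition at the one dose given, this pair cannot show whether the chloro group would matter in a compound with a clearly higher read-out. As far as these compounds go, it also remains open whether another group at this same place on the ring, such as fluoro, methoxy, an amine or a carboxylic acid, would move the number beyond the scatter, in either direction.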